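A few compounds are considered here, and "the series" means these few. Any claim that something is new, unique, unknown or untested is made for them only; others in the source may bear on it.

Measured in a functional assay on HeLa cells (Homo sapiens) for antiproliferative activity, read by MTT assay, with a stated time of 72 h; a lower number here means a stronger inhibitor, a higher number a weaker inhibitor:
- Compound 1 `C/C=C/C(=O)Nc1cccc(Oc2nc(Nc3ccn(C)n3)nc3c2CSCC3)c1`: > 50000 nM, a limit
- Compound 2 `C=C(F)C(=O)Nc1cccc(Oc2nc(Nc3ccn(C)n3)nc3c2CSCC3)c1`: > 50000 nM, a limit
- Compound 3 `C/C=C/C(=O)Nc1cccc(Oc2nc(Nc3cccc(OC)c3)nc3c2CSCC3)c1`: 13800 nM

Going by the values given here, compound 3 holds the only true number in this set. The rest of the set is described by the limit of > 50000 nM in this assay, at which 2 of the 3 values shown sit.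

Compound 4 `COc1cccc(Nc2nc3c(c(Oc4cccc(NC(=O)/C=C/C(C)C)c4)n2)CSCC3)c1` differs from compound 3 in one change: isopropyl in place of methyl on a double-bonded chain carbon bound to a double-bonded chain carbon. Put another way, 3-methylbut-1-en-1-yl replaces prop-1-en-1-yl.

One measured step alters this same group, a step that the two limits leave unreadable from compound 1 to compound 2, but it gives no size. The other, an at least 3.6-fold lower number from compound 1 to compound 3 (0.55 log units; beyond the scatter), concerns a different group, the one on the nitrogen on an aromatic ring. Neither sizes this change, so no step beyond the scatter is expected in this assay.

The expected step is a 1.1-fold higher number from compound 3 to compound 4 (0.04 log units; within the scatter).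

For compound 4 the estimated value is 15000 nM, with an expected range of 6000 nM to 40000 nM.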

Compound 4, half-maximal inhibitory concentration: > 50000 nM
Compound 4 was reported as a limit; the forecaster's own chance of this, stated with the estimate: 20%; middle value at least 3.3-fold (0.52 log units) away from the limit.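

This position is not indifferent to what sits on it: in this assay, isopropyl in place of methyl on a double-bonded chain carbon bound to a double-bonded chain carbon gives an at least 3.6-fold higher number from compound 3 to compound 4 (0.55 log units; beyond the scatter). A higher number means a weaker inhibitor, so here the swap from methyl to isopropyl costs activity. Compound 4 now joins the compounds reported only as a limit: the limit of > 50000 nM in this assay, at which 3 of the 4 values shown sit.

As far as these compounds go, what stays open is how a hydrogen or a dimethylaminomethyl group in place of methyl would behave. Whether either would give a lower number than methyl cannot be told from these compounds.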